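The source may report more compounds than this note shows. Statements on the series, on what has been measured and on what is new or still open speak of the compounds shown alone.

Measured so far in a functional assay on A549 cells (Homo sapiens) for antiproliferative activity, read by MTT assay; on this read-out lower numbers stand for stronger inhibition and higher numbers for weaker inhibition:
- compound 1 `COc1cc2c(Oc3ccc(NC(=O)Nc4ccc(Cl)c(C(F)(F)F)c4)cc3)ccnc2cc1OCCCCCCC(=O)NO`: 5020 nM
- compound 2 `COc1cc2c(Oc3ccc(NC(=O)NC4CCCCC4)cc3)ccnc2cc1OCCCCCCC(=O)NO`: 850 nM
- compound 3 `COc1cc2c(Oc3ccc(NC(=O)N/N=C/c4ccccc4)cc3)ccnc2cc1OCCCCCCC(=O)NO`: 3700 nM

Compound 1 gives 5020 nM, which places it at the high end of these numbers in company with compound 3. Only the cyclohexyl urea separates clearly from it, with a 5.9-fold lower number from compound 1 to compound 2 (0.77 log units; beyond the scatter).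

Compound 4 `COc1cc2c(Oc3ccc(NC(=O)NNC(=O)c4ccccc4)cc3)ccnc2cc1OCCCCCCC(=O)NO` has not yet been measured. Its structural change from compound 1 is benzamido in place of 4-chloro-3-(trifluoromethyl)phenyl on an amide-type nitrogen. The 4-chloro-3-(trifluoromethyl)phenyl group is thus lost, while one six-membered aromatic ring of carbon only remains in the entering benzamido group.

The nearest measured comparison also keeps such a ring in the entering group, and it shows a 1.4-fold lower number from compound 1 to compound 3 (0.13 log units; within the scatter). The non-aromatic case gives the larger move, and the return to an aromatic group gives a 4.4-fold higher number from compound 2 to compound 3 (0.64 log units; beyond the scatter). On these steps, leaving the 4-chloro-3-(trifluoromethyl)phenyl group may lower the number, but a drop as large as that of compound 2 is not expected while an aromatic ring stays.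

The expected step is small and downward in this assay, estimated as a 1.8-fold lower number from compound 1 to compound 4 (0.25 log units; within the scatter). For compound 4 the estimated value is 2800 nM, with an expected range of 1000 nM to 6500 nM.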

Compound 4, half-maximal inhibitory concentration: 2820 nM
Compound 4: the middle estimate sits 1.0-fold (0.00 log units) below what was measured; the measured number falls inside the stated range.
By their numbers in this assay, from the lowest: compound 2; then compounds 4, 3 and 1 (each within the scatter of the next).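

In this assay the benzamido group on this amide-type nitrogen, which brings a carbonyl, a hydrogen-bond donor and a hydrogen-bond acceptor, stays within the scatter of the 4-chloro-3-(trifluoromethyl)phenyl group, with a 1.8-fold lower number from compound 1 to compound 4 (0.25 log units; within the scatter), and of the group carried by compound 3, with a 1.3-fold lower number from compound 3 to compound 4 (0.12 log units; within the scatter). The cyclohexyl group remains apart, as a 3.3-fold higher number from compound 2 to compound 4 (0.52 log units; beyond the scatter) shows, so among these four compounds only compound 2, with a non-aromatic ring in the entering group, stands clear of the three with an aromatic ring, and none of those three goes against this. No measurement is at hand that explains this pattern or gives the added donor and acceptor of the benzamido group any part in it.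

Among these compounds, with cyclohexyl as the only non-aromatic group, it remains open whether the absence of aromaticity matters or something particular to that ring, and a cyclopentyl ring or an open n-hexyl chain would test this. On these data alone, it also remains open whether a pyridine ring in place of the benzene ring of the benzamido group would move the number at all.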